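This account rests on a few compounds, and the source may have more. Where it says the series, first, only, none or still open, it means among the compounds named here.

Results in a functional assay on A549 cells (Homo sapiens) for cytotoxicity, with a stated time of 60 h; a higher number here means that more compound is needed for the effect, a lower number that less compound is needed:
- Compound 1 `CCN(CC)C(=O)c1c(NC(=O)c2cncs2)sc2c1CCCC2`: > 30000 nM, a limit
- Compound 2 `CCN(CC)C(=O)c1c(NC(=O)c2ccco2)sc2c1CCCC2`: > 30000 nM, a limit
- Compound 3 `NC(=O)c1c(NC(=O)c2cccs2)sc2c1CCCC2`: < 30000 nM, a limit

None of these three results is an exact number. Compound 3 stands at < 30000 nM, which is a limit. For the measured compounds named here, it is the only compound at the limit of < 30000 nM in this assay, at which 1 of the 3 values shown sits, while the other two sit at the limit of > 30000 nM in this assay, at which 2 of the 3 values shown sit.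

Compound 4 `O=C(Nc1sc2c(c1C(=O)N1CCCCC1)CCCC2)c1cccs1` differs from compound 3 in one place: piperidin-1-yl in place of amino on a carbonyl carbon. Piperidin-1-yl takes the place of amino on a carbonyl carbon, so carbamoyl becomes (piperidin-1-yl)carbonyl.

Going by the values given here, the only measured step is a step that the two limits leave unreadable from compound 1 to compound 2. Among the compounds with values here, it concerns a different change, and its size cannot be read, so no measured step gives a size for this one. Compound 2 at > 30000 nM is a limit, and it is the sole ground for expecting a step in this assay toward needing more compound, of uncertain size. The estimated step is a step that the limit leaves unreadable from compound 3 to compound 4. For compound 4 the expected value is 28000 nM, with an estimated range from 9000 nM to 70000 nM. A report of only a limit is also expected to be quite likely.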

Compound 4, half-maximal effective concentration: 5100 nM
Beside the measured number, compound 4's estimate is 5.5-fold (0.74 log units) above it; the measured number lies below the stated range.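

Compound 3 is known only as a limit, < 30000 nM. The size of the step to compound 4, with piperidin-1-yl in place of amino on a carbonyl carbon, therefore cannot be read. The compounds shown leave open whether this change raises or lowers the amount of compound needed, and by how much.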